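The source may hold more compounds than are shown below. What is called first, only, known or untested is meant among the compounds shown, and "the series" means these compounds.

Measured compounds:

compound 1 `CC#C[C@H]1CN(S(=O)(=O)c2ccc(N)nc2)CCN1c1ccc(S(=O)(=O)NC)cn1` — 381 nM
compound 2 `CC#C[C@H]1CN(S(=O)(=O)c2ccc(N)nc2)CCN1c1ccc([C@@](O)(CO)C(F)(F)F)cc1` — 89 nM
compound 3 `C#CCC(O)(c1ccc(N2CCN(S(=O)(=O)c3ccc(N)nc3)C[C@@H]2C#CC)cc1)C(F)(F)F` — 130 nM

In an assay on cells (Hepatocyte) for inhibition of glucokinase regulatory protein (Mus musculus), with stated times of 20 min and 40 min (a higher number here means that more compound is needed for the effect, a lower number that less compound is needed), compound 3 stands second highest of the three numbers. Its nearest neighbour is compound 2, and the step of a 1.5-fold higher number from compound 2 to compound 3 (0.16 log units; within the scatter) lies within the scatter, so the two cannot be told apart. Compound 1 stands furthest away, with a number clearly higher than that of compound 3.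

Compound 4 `CC#C[C@H]1CN(S(=O)(=O)c2ccc(N)nc2)CCN1c1ccc(S(=O)(=O)NCC2CC2)cc1` is not yet measured. It differs from compound 3 in one place: a group of 8 heavy atoms (4 carbon, 1 nitrogen, 2 oxygen, 1 sulfur; one three-membered non-aromatic ring of carbon only) in place of a group of 9 heavy atoms (5 carbon, 1 oxygen, 3 fluorine; no ring), on an aromatic carbon. Within the data shown here, none of the measured steps changes this same kind of group, so no direct precedent exists. Among the measured compounds shown here, the only measured step, a 1.5-fold higher number from compound 2 to compound 3 (0.16 log units; within the scatter), exchanged one fluorinated carbinol for another and moved the number hardly at all. Compound 1, which carries a sulfamoyl group on a different ring, gives a higher number than compounds 2 and 3, which hints that a sulfamoyl group may cost some potency, but the rings differ, so this is weak guidance.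

Compound 4 is therefore expected to give a somewhat higher number, with the step of a 1.7-fold higher number from compound 3 to compound 4 (0.23 log units; within the scatter) estimated as the likely outcome. The estimate for compound 4 in this assay is 220 nM, within the range 70 nM to 700 nM.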

Compound 4, half-maximal effective concentration: 271 nM
Compound 4: middle estimate off by 1.2-fold (0.09 log units), on the low side; measured number inside the range.
By their numbers in this assay, from the lowest: compounds 2 and 3 (each within the scatter of the next); then compounds 4 and 1 (each within the scatter of the next).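

Among these compounds, at the aromatic carbon para to a large group, the (cyclopropylmethyl)sulfamoyl group brings the first step at this position that can be read in this assay: a 2.1-fold higher number from compound 3 to compound 4 (0.32 log units; beyond the scatter), and a 3.0-fold higher number from compound 2 to compound 4 (0.48 log units; beyond the scatter). Whereas the exchange of one fluorinated carbinol for the other could not be told apart from the scatter, this change of group type can, in both comparisons. The size of the steps is modest, so the position accepts this quite different group at a limited cost, though nothing shown here explains the rise.

On these data alone, it remains open whether the sulfamoyl link or the cyclopropylmethyl end accounts for the step. How a plain sulfamoyl group, a longer chain on its nitrogen or a carboxylic acid would compare at this position is also unanswered.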